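A few compounds are considered here, and "the series" means these few. Any claim that something is new, unique, unknown or untested is made for them only; others in the source may bear on it.

Measured so far in a functional assay on MCF7 cells (Homo sapiens) for antiproliferative activity, read by sulforhodamine B assay, with a stated time of 48 h; on this read-out lower numbers stand for stronger inhibition and higher numbers for weaker inhibition:
Compound 1 (`COc1ccc(C2C=C(c3cc(OC)c(OC)c(OC)c3)NC(=S)N2)cc1`) gives 103 nM
Compound 2 (`COc1cc(C2=CC(c3ccc(F)cc3)NC(=S)N2)cc(OC)c1OC`) gives 125 nM
Compound 3 (`COc1ccc(C2=NN(c3ccccc3)C(c3ccc(F)cc3)C2O)cc1`) gives 16 nM

Compound 2 stands level with compound 1 within the scatter, while compound 3 shows a clearly lower number than compound 2. Compound 4 (`COc1cc(C2=CC(c3ccc(Br)cc3)NC(=S)N2)cc(OC)c1OC`) has not yet been measured and carries a single change from compound 2: bromo in place of fluoro on an aromatic carbon (bromo in place of fluoro on an aromatic carbon, para to a large group). Among the compounds with values here, the only measured step that bears on this is a 1.2-fold higher number from compound 1 to compound 2 (0.08 log units; within the scatter) with fluoro in place of methoxy on an aromatic carbon, and it stays within the scatter. No exchange of fluoro for bromo has been measured, so this support is thin. On that basis, no step beyond the scatter is expected in this assay for this change. The expected result is a 1.0-fold lower number from compound 2 to compound 4 (0.02 log units; within the scatter) and this remains an estimate. Compound 4 is estimated at 120 nM with an expected range from 50 nM to 290 nM in a later measurement.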

Compound 4, half-maximal inhibitory concentration: 77 nM
Beside the measured number, compound 4's estimate is 1.6-fold (0.19 log units) above it; measured number inside the range.
By their numbers in this assay, from the lowest: compound 3; then compounds 4, 1 and 2 (each within the scatter of the next).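

In this assay the exchange of 4-fluorophenyl for 4-bromophenyl gives a 1.6-fold lower number from compound 2 to compound 4 (0.21 log units; within the scatter) and so stays within the scatter, which shows that this place, para to a large group, accepts bromo as readily as fluoro in this series. Bromo set directly against methoxy gives a 1.3-fold lower number from compound 1 to compound 4 (0.13 log units; within the scatter) and is also within the scatter, so methoxy, fluoro and bromo now all read alike here, and the earlier compounds alone could show this only for the first two. Nothing at hand explains why these three groups read alike at this place.

On these data alone, what an amine, a carboxylic acid or a longer chain would do at this place remains open. Also open, as far as these compounds go, is whether the same exchange would read alike on the core of compound 3, which carries a 4-fluorophenyl group of its own.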